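Swapping Bromo for Methyl: No Large Shift Expected

The source may hold more compounds than are shown below. What is called first, only, known or untested is meant among the compounds shown, and "the series" means these compounds.

Of the compounds shown here, three have been measured in a functional assay on NCI-H1975 cells (Homo sapiens) for antiproliferative activity, read by MTT assay, with a stated time of 72 h; a lower number here means a stronger inhibitor, a higher number a weaker inhibitor. Compound 1 `COc1ccc(Nc2ncnc3cc(OC)c(OCCCCC(=O)Nc4ccc(S(N)(=O)=O)cc4)cc23)cc1OC` gives 9230 nM. Compound 2 `NS(=O)(=O)c1ccc(NC(=S)Nc2ccc3ncnc(Nc4ccc(Cl)c(C(F)(F)F)c4)c3c2)cc1` gives 11800 nM, and compound 3 `NS(=O)(=O)c1ccc(NC(=S)Nc2ccc3ncnc(Nc4cccc(Br)c4)c3c2)cc1` gives 11000 nM. All three numbers sit close together: the step of a 1.1-fold lower number from compound 2 to compound 3 (0.03 log units; within the scatter) replaces one aryl group on a nitrogen by another and moves nothing beyond the scatter, and the gap between compound 1 and compound 3 is likewise within the scatter, so compound 3 cannot be called stronger or weaker than either of its neighbours.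

Compound 4 `Cc1cccc(Nc2ncnc3ccc(NC(=S)Nc4ccc(S(N)(=O)=O)cc4)cc23)c1` differs from compound 3 in one place: methyl in place of bromo on an aromatic carbon. Going by the values given here, the only measured step that bears on this part of the molecule is a 1.1-fold lower number from compound 2 to compound 3 (0.03 log units; within the scatter), in which a larger change of the same aryl group left the number where it was. On that basis no move beyond the scatter is expected in either direction, and the estimated step is no change at the digits printed from compound 3 to compound 4 (within the scatter). Compound 4 is therefore expected to give 11000 nM in this assay, with a range from 4000 nM to 30000 nM.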

Compound 4, half-maximal inhibitory concentration: 35400 nM
Compound 4: the middle estimate sits 3.2-fold (0.51 log units) below what was measured; the measured number lies above the stated range.
By their numbers in this assay, from the lowest: compounds 1, 3 and 2 (each within the scatter of the next); then compound 4.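

Going by these compounds alone, the aryl group on the nitrogen is not as free to change as the earlier compounds suggested: in this assay there is a 3.2-fold higher number from compound 3 to compound 4 (0.51 log units; beyond the scatter), even though bromo and methyl each count as 1 heavy atom and neither adds a ring or a charge. The larger replacement of the whole aryl group gives a similar result, with a 3.0-fold higher number from compound 2 to compound 4 (0.48 log units; beyond the scatter), whereas a 1.1-fold lower number from compound 2 to compound 3 (0.03 log units; within the scatter) stayed small, so 3-methylphenyl stands apart from both halogen-bearing aryl groups. No measurement here explains why methyl behaves differently from bromo on this aromatic carbon.

On these data alone, it remains open whether this rise belongs to methyl alone or would also appear with an amine or a nitrile on the same carbon. How a hydroxyl or a longer chain such as propyl would stand against compound 3 is also unresolved.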